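Amide in Place of Nitrile on an Inactive Core

The source may hold more compounds than are shown below. What is called first, only, known or untested is meant among the compounds shown, and "the series" means these compounds.

Compound 1, `Cc1cc(C#N)nc(NNC(=O)Nc2cc(Cl)nc(Cl)c2)c1`: > 6600 nM
Compound 2, `Cc1cc(NNC(=O)Nc2cc(Cl)nc(Cl)c2)nc(C(=O)N(C)C)c1`: > 19000 nM

In a functional assay on CHO cells for antagonist activity at sphingosine 1-phosphate receptor 2 (Homo sapiens), read by fluorescence and calcium flux, with a stated time of 3 min (a lower number here means a stronger inhibitor, a higher number a weaker inhibitor), compound 1 reaches only a limit, > 6600 nM. Compound 2 likewise reaches only a limit in this assay, > 19000 nM. The step that the two limits leave unreadable from compound 1 to compound 2 therefore has no readable size; what is known is the limit of > 6600 nM in this assay, at which 1 of the 2 values shown sits, and (the limit of > 19000 nM in this assay, at which 1 of the 2 values shown sits). Compound 3, `Cc1cc(NNC(=O)Nc2cc(Cl)nc(Cl)c2)nc(C(=O)N(C)C2CC2)c1`, differs from compound 1 by cyclopropyl(methyl)carbamoyl in place of cyano on an aromatic carbon. Only the unreadable step from compound 1 to compound 2 bears on this change, so no direction can be read for it in this assay. Compound 3 is expected to give 20000 nM (range 5000 nM to 100000 nM), an expected step that the limit leaves unreadable from compound 1 to compound 3 that most likely ends at a limit again.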

Compound 3, half-maximal inhibitory concentration: > 20000 nM
Compound 3 gave a limit, no number (the forecaster's own chance of this, stated with the estimate: 85%); the middle value lies on the limit itself.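

In this assay compound 3 gives only a limit, > 20000 nM. The steps to it from compound 1 and from compound 2 cannot be read. The compounds shown leave open whether any of these groups gives a measurable inhibitory potency on the shared core.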